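The compounds below may be only part of what the source reports. "The series", "measured", "known", "first", "only" and "open" are said of these compounds alone.

Among the measured compounds shown here, compound 2 `O=c1c(OCc2cccc(Cl)c2)c(-c2ccccc2)oc2cc(O)cc(O)c12` is the better tolerated of the two compounds measured so far. In an ADME assay on Huh-5-2 cells (Homo sapiens) for cytotoxicity, read by WST assay, with a stated time of 3 days (a higher number here means that more compound is tolerated, a lower number that less compound is tolerated), compound 2 gives 46000 nM, whereas compound 1 `O=c1c(OCc2ccccc2Br)c(-c2ccccc2)oc2cc(O)cc(O)c12` gives 12000 nM in this assay; the step of a 3.8-fold higher number from compound 1 to compound 2 (0.58 log units; beyond the scatter) lies beyond the scatter. Compound 3 `O=c1c(OCc2cccc(Br)c2)c(-c2ccccc2)oc2cc(O)cc(O)c12` has not yet been measured. It differs from compound 2 only by bromo in place of chloro on an aromatic carbon. For the measured compounds named here, the single measured step changes both the halogen and its position on the ring at once, so it does not isolate the effect of swapping one halogen for another at the same place; no measured step bears directly on the change from compound 2 to compound 3. An exchange of one halogen for a heavier one, with everything else kept the same, has in comparable series tended to give only small shifts in cell tolerance, so the expectation for this assay is a step no larger than the usual scatter, with no clear direction, a 1.2-fold lower number from compound 2 to compound 3 (0.06 log units; within the scatter). Compound 3 is therefore estimated at 40000 nM in this assay, within a range from 15000 nM to 100000 nM.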

Compound 3, half-maximal cytotoxic concentration: 15000 nM
Beside the measured number, compound 3's estimate is 2.7-fold (0.43 log units) above it, within the range that was stated.
By their numbers in this assay, from the lowest: compounds 1 and 3 (each within the scatter of the next); then compound 2.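

With the place on the ring held fixed, bromo in place of chloro gives a 3.1-fold lower number from compound 2 to compound 3 (0.49 log units; beyond the scatter) in this assay and so shows that the identity of the halogen alone can matter at this carbon. With the halogen held fixed as bromo, the change from 2-bromophenyl to 3-bromophenyl gives a 1.3-fold higher number from compound 1 to compound 3 (0.10 log units; within the scatter) and thus separates the two changes that were combined in the earlier step: here, moving the bromine leaves the number within the scatter, while changing the halogen does not. Nothing at hand explains why chloro and bromo differ here. Among the compounds shown here, still, this reading rests on only three compounds, with compound 2 alone standing apart from the other two, so it is not yet a rule for the series.

The compounds shown leave open whether the 2-chlorophenyl analogue would stand with compound 2 or with the two bromo compounds, which would test whether moving the halogen also makes no clear difference for chloro. They also leave open how fluoro, methyl or methoxy on the same aromatic carbon would compare with chloro and bromo.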